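The compounds below may be only part of what the source reports. "The series", "measured", "known", "first", "only" and "open" are said of these compounds alone.

Of the compounds shown here, three built on one shared core have been tested in a functional assay on GTL 16 cells for antiproliferative activity against GTL 16 cell line (Homo sapiens), read by CCK-8 assay, with a stated time of 72 h; on this read-out higher numbers stand for weaker inhibition and lower numbers for stronger inhibition. Compound 1 `O=C(Nc1cccc(-c2oc3cc(-c4ccc(F)cc4)ccc3c(=O)c2O)c1)c1ccccc1F` gives 17400 nM. Compound 2 `O=C(Nc1cccc(-c2oc3cc(-c4ccc(F)cc4)ccc3c(=O)c2O)c1)c1ccc(F)cc1` gives 14600 nM in this assay, and compound 3 `Cc1cc(C(=O)Nc2cccc(-c3oc4cc(-c5ccc(F)cc5)ccc4c(=O)c3O)c2)ccc1F` gives 12100 nM. Compound 3 carries the lowest of the three numbers, yet every step toward it is small: a 1.4-fold lower number from compound 1 to compound 3 (0.16 log units; within the scatter) and a 1.2-fold lower number from compound 2 to compound 3 (0.08 log units; within the scatter), while a 1.2-fold lower number from compound 1 to compound 2 (0.08 log units; within the scatter) likewise stays within the scatter. All three compounds differ only in the aryl group attached to the carbonyl carbon, and none of them separates from the others in this assay.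

Compound 4 `O=C(Nc1cccc(-c2oc3cc(-c4ccc(F)cc4)ccc3c(=O)c2O)c1)c1ccc(Cl)nc1` has not yet been measured in this assay. Its change from compound 3 is 6-chloropyridin-3-yl in place of 4-fluoro-3-methylphenyl on a carbonyl carbon. The three measured steps all alter the same aryl group on the carbonyl carbon, and all of them fall within the scatter, so one expects the step of a 1.0-fold lower number from compound 3 to compound 4 (0.00 log units; within the scatter) in this assay to stay within the scatter as well, with no clear direction. The estimated value for compound 4 in this assay is 12000 nM, with a range from 5000 nM to 30000 nM, and the measurement itself is now awaited.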

Compound 4, half-maximal inhibitory concentration: 7520 nM
Compound 4: the middle estimate sits 1.6-fold (0.20 log units) above what was measured; the measured number falls inside the stated range.
By their numbers in this assay, from the lowest: compounds 4, 3, 2 and 1 (each within the scatter of the next, the first and the last beyond it).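

In this assay the aryl group on the carbonyl carbon now yields a step that clears the scatter, a 2.3-fold lower number from compound 1 to compound 4 (0.36 log units; beyond the scatter), so this position is not entirely silent when 6-chloropyridin-3-yl takes the place of 2-fluorophenyl. The separation holds for that one pair only and is modest: against the other two aryl groups the same entering group stays within the scatter, with a 1.6-fold lower number from compound 3 to compound 4 (0.21 log units; within the scatter) and a 1.9-fold lower number from compound 2 to compound 4 (0.29 log units; within the scatter), so no ranking of the four aryl groups follows beyond that single pair. The entering group is the only one of the four with a ring hetero atom and a hydrogen-bond acceptor, but no measurement shown ties the step to either of these features or to the chlorine, and nothing at hand explains it.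

The compounds shown leave open whether the ring nitrogen or the chlorine matters here, a question that plain pyridin-3-yl and 4-chlorophenyl at the same carbonyl carbon would address. They also leave open how this position responds to groups of a different kind, such as an amine, a carboxylic acid or a longer alkyl chain on the aryl ring.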